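Shorter Chains on the Triazole of a Quinoline Core

This account rests on a few compounds, and the source may have more. Where it says the series, first, only, none or still open, it means among the compounds named here.

Measured so far:
- Compound 1, `COc1nc2ccc(Br)cc2cc1C(c1ccccc1)n1cc(-c2ccc(OC(F)(F)F)cc2)nn1`: 14.8%
- Compound 2, `CCCCCCc1cn(C(c2ccccc2)c2cc3cc(Br)ccc3nc2OC)nn1`: 7.17%
- Compound 3, `CCCCCc1cn(C(c2ccccc2)c2cc3cc(Br)ccc3nc2OC)nn1`: 10.5%

These three compounds share one core and differ only in the group on an aromatic carbon of the triazole ring. In an ADME assay on SK-OV-3 cells (Homo sapiens) for cytotoxicity, read by sulforhodamine B assay, with a stated time of 48 h, tested at 10 uM (a lower number here means less inhibition, a higher number more inhibition at the concentration tested (going by the name of the read-out)), compound 1 gives 14.8%, the highest of the three numbers, though its gaps to the two others both lie within the usual scatter. Replacing the aryl group by a hexyl chain gave a number 7.6 percentage points lower from compound 1 to compound 2 (within the scatter), and replacing it by a pentyl chain gave a number 4.3 percentage points lower from compound 1 to compound 3 (within the scatter); between the two chains the change was a number 3.3 percentage points higher from compound 2 to compound 3 (within the scatter).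

Compound 4, `CCCc1cn(C(c2ccccc2)c2cc3cc(Br)ccc3nc2OC)nn1`, is the next step from compound 1: propyl in place of 4-(trifluoromethoxy)phenyl on an aromatic carbon. The two steps that bear on it are those from compound 1 to compounds 2 and 3, where the aryl group was also exchanged for a plain chain, and both stayed within the scatter. Within the data shown here, no step in this small set moved the read-out beyond the scatter, so a shorter chain is expected to behave much like the longer ones.

Compound 4 is therefore estimated at 9%, with a range from 0% to 20%, which as a step means an expected a number 5.8 percentage points lower from compound 1 to compound 4 (within the scatter).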

Compound 4, a percentage reported as inhibition, at one concentration (the size of the read-out at that concentration, not a potency): 11.2%
Compound 4: middle estimate off by 2.2 percentage points, on the low side, within the range that was stated.
By their numbers in this assay, from the lowest: compounds 2, 3, 4 and 1 (each within the scatter of the next).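

Exchanging 4-(trifluoromethoxy)phenyl, with its 11 heavy atoms and its ring, for propyl, with 3 heavy atoms and no ring, gives in this assay a number 3.6 percentage points lower from compound 1 to compound 4 (within the scatter), so even this large cut in the size of the group on the aromatic carbon of the five-membered ring leaves the read-out within the scatter. The chains agree with this: the steps are a number 0.7 percentage points higher from compound 3 to compound 4 (within the scatter) and a number 4 percentage points higher from compound 2 to compound 4 (within the scatter), so propyl, pentyl and hexyl cannot be told apart here, and the earlier pair of hexyl and pentyl alone covered a much narrower span of chain length. Nothing measured here gives a reason for this flat picture.

The compounds shown leave open whether a group of another kind at this position, such as an amine or a carboxylic acid, or a chain outside this span, such as methyl or decyl, would carry the read-out beyond the scatter. Going by these compounds, a reading at one concentration also gives no potency, so how these compounds would compare across a range of concentrations stays open.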